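A few compounds are considered here, and "the series" means these few. Any claim that something is new, unique, unknown or untested is made for them only; others in the source may bear on it.

Measured so far in an assay on isolated protein with Bile acid receptor (Homo sapiens) as the target; a higher number here means that more compound is needed for the effect, a lower number that less compound is needed:
compound 1, `COC(=O)/C=C/c1cccc(N(Cc2ccc(/C=C/c3c(C)cc(C)cc3C)cc2)C(=O)NC(C)C)c1`: 431 nM
compound 2, `COC(=O)/C=C/c1cccc(N(Cc2ccc(-c3cccc(OC)c3)cc2)C(=O)NC(C)C)c1`: 1370 nM
compound 3, `COC(=O)/C=C/c1cccc(N(Cc2ccc(/C=C/c3cccc(F)c3)cc2)C(=O)NC(C)C)c1`: 467 nM

Compound 2 gives the highest of the three numbers in this assay: the step of a 3.2-fold higher number from compound 1 to compound 2 (0.50 log units; beyond the scatter) and the step of a 2.9-fold lower number from compound 2 to compound 3 (0.47 log units; beyond the scatter) both lie beyond the scatter, while a 1.1-fold higher number from compound 1 to compound 3 (0.03 log units; within the scatter) lies within it. Compound 4, `COC(=O)/C=C/c1cccc(N(Cc2ccc(-c3cccc(OC)c3)cc2)C(=O)C(C)C)c1`, differs from compound 2 as follows: isopropyl in place of isopropylamino on a carbonyl carbon. For the measured compounds named here, none of the three measured steps touches this part of the molecule; all of them vary the group on the aromatic carbon at the far end of the shared core, so no measured step bears on the change. The data therefore support no direction, and the step of a 1.5-fold higher number from compound 2 to compound 4 (0.16 log units; within the scatter) is estimated only as a modest move with a wide range. Compound 4 is expected at 2000 nM, between 600 nM and 7000 nM.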

Compound 4, half-maximal effective concentration: 72 nM
For compound 4 the middle estimate is 28-fold (1.44 log units) above the measured one; the whole stated range lies above it.
By their numbers in this assay, from the lowest: compound 4; then compounds 1 and 3 (each within the scatter of the next); then compound 2.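

In this assay, for the compounds shown here, the group on the carbonyl carbon emerges as a sensitive position, with a 19-fold lower number from compound 2 to compound 4 (1.28 log units; beyond the scatter) for isopropyl in place of isopropylamino, a larger move than any step seen among the earlier compounds. The exchange takes out a nitrogen and the one hydrogen-bond donor of the leaving group. No available evidence says what lies behind the shift. Still open, from the compounds shown here alone, is whether the same exchange carries over to the ethenyl-linked groups of compound 1 and compound 3, and how a cyclopropyl group or a longer chain on this carbonyl carbon would read.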